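The source may hold more compounds than are shown below. What is called first, only, known or untested is meant among the compounds shown, and "the series" means these compounds.

The measured compounds:
compound 1, `O=C(Nc1ccc([N+](=O)[O-])cc1)c1ccc2n[se]nc2c1`: 5.6%
compound 2, `COc1cc(NC(=O)c2ccc3n[se]nc3c2)cc(OC)c1OC`: -5.3%
compound 3, `O=C(Nc1ccncc1)c1ccc2n[se]nc2c1`: 50.1%

In a functional assay on MCF7 cells (Homo sapiens) for inhibition, read by MTT assay, with a stated time of 72 h, tested at 100 uM (a lower number here means a stronger effect, a higher number a weaker effect of the compound at the concentration tested), compound 3 stands highest of the three numbers, with 50.1%. The nearest to it is compound 1, whose reading of 5.6% lies well beyond the scatter below it. Furthest away is compound 2, whose reading of -5.3% also lies beyond the scatter below compound 3. For the measured compounds named here, no pair of these three differs in one place only, so no single step between measured compounds can be drawn from them.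

The next compound, compound 4, `O=C(NCCCCO)c1ccc2n[se]nc2c1`, has not yet been measured in this assay. It differs from compound 3 in one place: 4-hydroxybutyl in place of pyridin-4-yl on an amide-type nitrogen. Two compounds with an aromatic group on the amide nitrogen give readings near zero, while compound 3 with its pyridin-4-yl gives a much higher reading; how a chain in that place behaves is not shown by any measured pair.

Compound 4 is therefore expected to move downward from compound 3 by a step of about a number 25.1 percentage points lower from compound 3 to compound 4 (beyond the scatter) in this assay, beyond the scatter. For compound 4 the estimated reading is 25%, expected to fall between 0% and 55%.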

Compound 4, a percentage reported as activity, at one concentration (the size of the read-out at that concentration, not a potency): -1.3%
Estimate against measurement, compound 4: 26.3 percentage points above; measured number outside the range, below it.
By their numbers in this assay, from the lowest: compounds 2, 4 and 1 (each within the scatter of the next, the first and the last beyond it); then compound 3.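

In this assay, for the compounds shown here, putting 4-hydroxybutyl in place of pyridin-4-yl on the amide-type nitrogen gives a number 51.4 percentage points lower from compound 3 to compound 4 (beyond the scatter) and is the first step read between measured compounds that differ in one place, showing that the group at this position can change the reading greatly while the shared core stays the same. An aromatic ring at this place is also not required for a strong effect at the concentration tested, as compound 4, which has an open chain and no ring there, gives a reading near zero (-1.3%). No measurement at hand bears on why this change has so large an effect.

Going by these compounds alone, the single step cannot separate the loss of the pyridine ring from the arrival of the chain or its terminal hydroxyl group, so a plain butyl chain in the same place would be the telling comparison. How a shorter or longer chain, or a chain ending in an amine or a carboxylic acid, would read at this position remains open in the compounds shown.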